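This account rests on a few compounds, and the source may have more. Where it says the series, first, only, none or still open, it means among the compounds named here.

Among the compounds with values here, compound 2 `Cc1cccc(NC(=O)c2cnn(-c3ccc(F)cc3)c2C)c1` gives 5700 nM in a functional assay with Homo sapiens as the target (a lower number here means a stronger inhibitor, a higher number a weaker inhibitor), the higher of the two numbers measured so far. Compound 1 `Cc1ccc(NC(=O)c2cnn(-c3ccc(F)cc3)c2C)cc1` gives 540 nM, and the step of an 11-fold higher number from compound 1 to compound 2 (1.02 log units; beyond the scatter) shows that exchanging one methylphenyl for another can matter greatly. Compound 3 `Cc1c(C(=O)Nc2ccccc2F)cnn1-c1ccc(F)cc1` differs from compound 2 by 2-fluorophenyl in place of 3-methylphenyl on an amide-type nitrogen. That single measured step concerns methyl groups, not fluorine, so it bears only loosely on this change and gives no clear direction. For compound 3 the step of a 1.4-fold lower number from compound 2 to compound 3 (0.15 log units; within the scatter) is expected to stay within the scatter, though with wide uncertainty. Compound 3 is therefore estimated at 4000 nM, between 800 nM and 20000 nM.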

Compound 3, half-maximal inhibitory concentration: 4000 nM
Beside the measured number, compound 3's estimate shows no gap at the digits printed; low and high end bracket the measured number.
By their numbers in this assay, from the lowest: compound 1; then compounds 3 and 2 (each within the scatter of the next).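

On the amide-type nitrogen, 2-fluorophenyl and 3-methylphenyl cannot be told apart in this assay (a 1.4-fold lower number from compound 2 to compound 3 (0.15 log units; within the scatter)). Set against 4-methylphenyl, 2-fluorophenyl gives a 7.4-fold higher number from compound 1 to compound 3 (0.87 log units; beyond the scatter), so among these three groups only the 4-methylphenyl of compound 1 stands clear of the others. Nothing measured here explains these differences.

Still open, from the compounds shown here alone, is whether other groups on this nitrogen, such as 4-ethylphenyl or a phenyl ring carrying a carboxylic acid or an amine, would match compound 1 or give a lower number.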